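The source may hold more compounds than are shown below. What is called first, only, known or untested is meant among the compounds shown, and "the series" means these compounds.

Measured compounds:
Compound 1 `CN(C)CCn1cnnc1-c1cc(Oc2ccc(NC(=O)N/N=C/c3ccc(Cl)cc3)cc2F)ccn1` gives 1370 nM in a functional assay on U-87MG ATCC cells (Homo sapiens) for cytotoxicity, read by MTT assay, with a stated time of 72 h; a lower number here means a stronger inhibitor, a higher number a weaker inhibitor.
Compound 2 `CN(C)CCn1cnnc1-c1cc(Oc2ccc(NC(=O)N/N=C/c3c[nH]c4ccccc34)cc2F)ccn1` gives 690 nM in this assay.
Compound 3 `COc1ccc(/C=N/NC(=O)Nc2ccc(Oc3ccnc(-c4nncn4CCN(C)C)c3)c(F)c2)c(OC)c1OC` gives 7650 nM in this assay.

Compound 3 has the highest number of the three, as a 5.6-fold higher number from compound 1 to compound 3 (0.75 log units; beyond the scatter) and an 11-fold higher number from compound 2 to compound 3 (1.04 log units; beyond the scatter) show. Compound 4 `COc1cc(/C=N/NC(=O)Nc2ccc(Oc3ccnc(-c4nncn4CCN(C)C)c3)c(F)c2)cc(OC)c1OC` is built from the same atoms as compound 3, joined differently: 3,4,5-trimethoxyphenyl in place of 2,3,4-trimethoxyphenyl on a carbon with a double bond to nitrogen. Among the compounds with values here, no measured step moves groups around within the same ring; the measured steps only replace one whole group by another, so none bears closely on this change. With no guide, a step beyond the scatter in this assay is not expected in either direction. Compound 4 is therefore estimated at 5500 nM, with a range from 1800 nM to 16000 nM. This estimate means an expected step of a 1.4-fold lower number from compound 3 to compound 4 (0.14 log units; within the scatter).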

Compound 4, half-maximal inhibitory concentration: 22500 nM
For compound 4 the middle estimate is 4.1-fold (0.61 log units) below the measured one; the measured number lies above the stated range.
By their numbers in this assay, from the lowest: compounds 2 and 1 (each within the scatter of the next); then compound 3; then compound 4.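

In this assay, replacing 2,3,4-trimethoxyphenyl with 3,4,5-trimethoxyphenyl, which has the same atoms joined differently, gives a 2.9-fold higher number from compound 3 to compound 4 (0.47 log units; beyond the scatter), so at this carbon the arrangement on the ring matters, not only the kind of group. The 3,4,5-trimethoxyphenyl group also compares poorly with the other groups here, with a 33-fold higher number from compound 2 to compound 4 (1.51 log units; beyond the scatter) and a 16-fold higher number from compound 1 to compound 4 (1.22 log units; beyond the scatter). No measured evidence explains these differences.

On these data alone, it remains open whether a phenyl ring carrying a single methoxy group, or a pyridine ring, at this carbon would give a number as low as those of 4-chlorophenyl and 1H-indol-3-yl.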